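Replacing 2-bromophenyl with 4-hydroxyphenyl

A few compounds are considered here, and "the series" means these few. Any claim that something is new, unique, unknown or untested is made for them only; others in the source may bear on it.

In a functional assay on MCF7 cells (Homo sapiens) for cytotoxicity, read by MTT assay, with a stated time of 72 h (a higher number here means a weaker inhibitor, a lower number a stronger inhibitor), compound 1 (`COc1cccc(/C=C2\CCC/C(=C\c3ccc(Cl)c(Cl)c3)C2=O)c1OC`) gives 9000 nM, compound 2 (`COc1cc(/C=C2\CCC/C(=C\c3cccc(OC)c3OC)C2=O)cc(OC)c1`) gives 1700 nM and compound 3 (`COc1ccc(/C=C2\CCC/C(=C\c3ccccc3Br)C2=O)cc1OC`) gives 9500 nM. Compound 3 and compound 1 lie within the scatter of each other, while compound 2 has a lower number, beyond the scatter from both. Compound 4 (`COc1ccc(/C=C2\CCC/C(=C\c3ccc(O)cc3)C2=O)cc1OC`) differs from compound 3 in one place: 4-hydroxyphenyl in place of 2-bromophenyl on a double-bonded chain carbon bound to a double-bonded ring carbon. It carries 4-hydroxyphenyl in place of 2-bromophenyl on a double-bonded chain carbon bound to a double-bonded ring carbon. Going by the values given here, no measured compound carries this group, so the expectation is uncertain. In this assay, a modest move to a lower number is expected, a 2.4-fold lower number from compound 3 to compound 4 (0.38 log units; beyond the scatter). Compound 4 is estimated at 4000 nM, with an expected range of 1200 nM to 12000 nM.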

Compound 4, half-maximal inhibitory concentration: 17000 nM
Estimate against measurement, compound 4: 4.3-fold (0.63 log units) below, outside the stated range (above it).
By their numbers in this assay, from the lowest: compound 2; then compounds 1, 3 and 4 (each within the scatter of the next).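

In this assay, placing 4-hydroxyphenyl in place of 2-bromophenyl on a double-bonded chain carbon bound to a double-bonded ring carbon gives a 1.8-fold higher number from compound 3 to compound 4 (0.25 log units; within the scatter), a step within the scatter. For this one pair, exchanging the bromine for a hydroxyl, and moving the substituent's place on the ring, therefore produces no readable change in cytotoxicity. No measurement shown here offers an explanation for this result. Going by these compounds, whether an amine or a carboxylic acid in place of the hydroxyl would read the same remains open. So does whether this change would also be silent with the other aryl group of compound 2.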